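The source may report more compounds than this note shows. Statements on the series, on what has been measured and on what is new or still open speak of the compounds shown alone.

Compound 1 `Cc1n[nH]c2nc(-c3ccc(NS(=O)(=O)c4cc(Cl)ccc4F)cc3)nc(OCCC(=O)N(C)C)c12`: 438 nM in an assay for inhibition of serine/threonine-protein kinase Sgk1 (Homo sapiens), with stated times of 30 min and 60 min, in the presence of a further agent that is not named here; a higher number here means a weaker inhibitor, a lower number a stronger inhibitor
Compound 2 `Cc1n[nH]c2nc(-c3ccc(NS(=O)(=O)c4cc(Cl)ccc4F)cc3)nc(OCC3(CN)COC3)c12`: 1 nM in this assay

Within this pair compound 2 stands at the lowest number, and the only measured step, a 440-fold lower number from compound 1 to compound 2 (2.64 log units; beyond the scatter), separates the two.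

Compound 3 `Cc1n[nH]c2nc(-c3ccc(NS(=O)(=O)c4cc(Cl)ccc4F)cc3)nc(OC3CCOCC3)c12` differs from compound 2 in one place: oxan-4-yl in place of (3-(aminomethyl)oxetan-3-yl)methyl on an oxygen on an aromatic ring. The aminomethyl thus leaves, and the ring that enters carries no amine. For the measured compounds named here, only one measured step bears on such a change, a 440-fold lower number from compound 1 to compound 2 (2.64 log units; beyond the scatter), in which the aminomethyl oxetane came in for a group without an amine and the number fell by a wide margin. Compound 3 again lacks the amine, so that step read backwards is the closest available guide, although the entering oxan-4-yl is not the group found in compound 1 and the match is loose. A large rise in this assay is therefore expected, a 200-fold higher number from compound 2 to compound 3 (2.30 log units; beyond the scatter). Compound 3 is estimated at 200 nM, with a range from 20 nM to 2000 nM.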

Compound 3, half-maximal inhibitory concentration: 14 nM
Compound 3: middle estimate off by 14-fold (1.15 log units), on the high side; the measured number lies below the stated range.
By their numbers in this assay, from the lowest: compound 2; then compound 3; then compound 1.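

In this assay, the oxan-4-yl group on the oxygen on the aromatic ring gives a strong inhibitor without any amine, even though there is a 14-fold higher number from compound 2 to compound 3 (1.15 log units; beyond the scatter) and the change is clearly a loss. Against the other amine-free compound the same group gives a 31-fold lower number from compound 1 to compound 3 (1.50 log units; beyond the scatter) and so stands well apart from it. The amine of the (3-(aminomethyl)oxetan-3-yl)methyl group therefore cannot be the whole story behind the low number of compound 2, since two compounds without an amine differ widely at this one position, and nothing at hand explains why these groups rank as they do.

Going from compound 2 to compound 3 changes the ring, the link to the oxygen and the amine all at once, so the share of each in the loss stays unknown. As far as these compounds go, an aminomethyl group placed on the oxan-4-yl ring, or a plain oxetane ring without its aminomethyl group, would be needed to separate these parts, and how either would read remains open.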